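The compounds below may be only part of what the source reports. "The series", "measured", "known", "first", "only" and "open" are said of these compounds alone.

Compound 1 `COc1ccc(C(=O)c2ccc(OC)c3c2OC(C)(C)C=C3)c(NC(=O)CN)c1` gives 270 nM in a functional assay on A549 cells (Homo sapiens) for antiproliferative activity, read by MTT assay, with a stated time of 48 h; a lower number here means a stronger inhibitor, a higher number a weaker inhibitor. Compound 2 `COc1ccc(C(=O)c2ccc(OC)c3c2C=CC(C)(C)O3)c(NC(=O)CN)c1` has the same atoms joined differently; the difference between the two cores is not broken down here. In this assay compound 2 gives 420 nM, which sits within the scatter of compound 1. Compound 3 `CNCC(=O)Nc1cc(OC)ccc1C(=O)c1ccc(OC)c2c1OC(C)(C)C=C2` carries methyl in place of hydrogen on an amine nitrogen relative to compound 1, and in this assay compound 3 gives 620 nM, a step of a 2.3-fold higher number from compound 1 to compound 3 (0.36 log units; beyond the scatter). Compound 4 `CNCC(=O)Nc1cc(OC)ccc1C(=O)c1ccc(OC)c2c1C=CC(C)(C)O2` is not yet measured and carries methyl in place of hydrogen on an amine nitrogen relative to compound 2, the same change made on the core of compound 2, at a place described in the same words. The step from compound 2 to compound 4 in this assay is expected to be a 2.3-fold higher number from compound 2 to compound 4 (0.35 log units; beyond the scatter), resting on the measured step of a 2.3-fold higher number from compound 1 to compound 3 (0.36 log units; beyond the scatter) on the core of compound 1. Compound 4 is therefore estimated at 950 nM in this assay, expected to fall between 500 nM and 1800 nM.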

Compound 4, half-maximal inhibitory concentration: 1370 nM
Compound 4: middle estimate off by 1.4-fold (0.16 log units), on the low side, and the stated range covers the measured number.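

The step of a 3.3-fold higher number from compound 2 to compound 4 (0.51 log units; beyond the scatter) in this assay comes from methyl in place of hydrogen on an amine nitrogen. Set beside the earlier step, the change carries from one core to the other with no difference that can be told apart: the same change on two cores in this assay, a 2.3-fold higher number (0.36 log units; beyond the scatter) from compound 1 to compound 3 and a 3.3-fold higher number (0.51 log units; beyond the scatter) from compound 2 to compound 4, 1.4-fold (0.15 log units) apart, within the scatter of two such steps
This rests on a single pair per core in one cell line, so it does not show that the step would hold on other cores or with other groups on that nitrogen, and it gives no reason for the rise.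

The compounds shown leave open how ethyl or dimethylamino at the same nitrogen would read on either core. Also open, on these data alone, is how a longer chain in place of (aminomethyl)carbonyl would read.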